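Dimethylamino in place of ethyl on the acylamino chain

A few compounds are considered here, and "the series" means these few. Any claim that something is new, unique, unknown or untested is made for them only; others in the source may bear on it.

- compound 1 `CCCCCC(=O)NCC(=O)N(C)c1ccc(Cl)cc1C(=O)c1ccccc1Cl`: 1.9 mg/kg
- compound 2 `CCCC(=O)NCC(=O)N(C)c1ccc(Cl)cc1C(=O)c1ccccc1Cl`: 0.98 mg/kg

In a functional assay on the whole organism for antagonist activity, with Mus musculus as the target (a higher number here means that more compound is needed for the effect, a lower number that less compound is needed), compound 2 gives 0.98 mg/kg. Within the data shown here, only one other number is available for comparison, and compound 2 cannot be separated from compound 1, since the two values lie within the scatter of each other.

The next compound to be measured is compound 3 `CN(C)CC(=O)NCC(=O)N(C)c1ccc(Cl)cc1C(=O)c1ccccc1Cl`. The change from compound 2 is dimethylamino in place of ethyl on a saturated chain carbon bound to a carbonyl carbon, with dimethylamino in place of ethyl on a saturated chain carbon bound to a carbonyl carbon.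

Among the measured compounds shown here, one measured step bears on this, and only indirectly: a 1.9-fold lower number from compound 1 to compound 2 (0.29 log units; within the scatter). It replaces ethyl with hydrogen on a saturated chain carbon, three bonds along the chain from a carbonyl carbon, at the same end of the molecule. For the measured compounds named here, no measured compound carries dimethylamino, so the direction of any change cannot be derived from the data. No shift beyond the scatter is expected in this assay, though the range is kept wide on both sides.

The expected change is a 1.2-fold higher number from compound 2 to compound 3 (0.09 log units; within the scatter). For compound 3 the estimated value is 1.2 mg/kg, with an expected range of 0.3 mg/kg to 5 mg/kg.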

Compound 3, dose for half-maximal effect: 2.6 mg/kg
Beside the measured number, compound 3's estimate is 2.2-fold (0.34 log units) below it, and the stated range covers the measured number.
By their numbers in this assay, from the lowest: compounds 2, 1 and 3 (each within the scatter of the next, the first and the last beyond it).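

In this assay, among these compounds, this position gives its first step beyond the scatter, a 2.7-fold higher number from compound 2 to compound 3 (0.42 log units; beyond the scatter), so dimethylamino in place of ethyl on a saturated chain carbon bound to a carbonyl carbon does register here, though the step is modest and separates only this pair. Measured against the butyl of the longer chain, the same group gives a 1.4-fold higher number from compound 1 to compound 3 (0.14 log units; within the scatter), which leaves compound 3 inseparable from compound 1 and shows that the entering nitrogen does not set compound 3 apart from every chain in the series. Nothing measured accounts for the step from ethyl to dimethylamino, and no supporting data on it are available.

Open, as far as these compounds go, is whether a smaller amine such as methylamino, a cyclic amine such as piperidine, or a carboxylic acid on this carbon would sit with compound 2 or with compound 3. Also open, from the compounds shown here alone, is whether the shift follows the nitrogen itself or only the branched shape of the group, which an isopropyl on the same carbon, carrying no nitrogen, would help to separate.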